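From 1,3-Thiazol-2-yl to 5-Methyl-1,2-oxazol-3-yl on a Sulfonamide

The source may hold more compounds than are shown below. What is called first, only, known or untested is meant among the compounds shown, and "the series" means these compounds.

Of the compounds shown here, two have been tested in a functional assay on MCF7 cells (Homo sapiens) for cytotoxicity, read by sulforhodamine B assay, with a stated time of 72 h; on this read-out lower numbers stand for stronger inhibition and higher numbers for weaker inhibition. Compound 1 `O=C1N=C(Nc2ccc(S(=O)(=O)Nc3nccs3)cc2)S/C1=C/c1coc2ccccc2c1=O` reaches only a limit: in this assay compound 1 gives > 100000 nM, which is the edge of the assay rather than a measured number (the limit of > 100000 nM in this assay, at which 1 of the 2 values shown sits). Compound 2 `CCOC1Oc2ccccc2C(=O)/C1=C/Nc1ccc(S(N)(=O)=O)cc1`, built on a different core, gives 22200 nM in this assay. Going by the values given here, no two measured compounds differ in a single place, so no step has been quantified yet. Compound 3 `Cc1cc(NS(=O)(=O)c2ccc(NC3=NC(=O)/C(=C\c4coc5ccccc5c4=O)S3)cc2)no1` is not yet measured; it differs from compound 1 in one place, (5-methyl-1,2-oxazol-3-yl in place of 1,3-thiazol-2-yl on a sulfonamide nitrogen), that is, 5-methyl-1,2-oxazol-3-yl in place of 1,3-thiazol-2-yl on a sulfonamide nitrogen. Because compound 1 gives only the limit > 100000 nM, this single exchange is not expected to move the read-out beyond the usual scatter. Compound 3 is therefore expected near 120000 nM, within 30000 nM to 400000 nM. The expected step that the limit leaves unreadable from compound 1 to compound 3 is small.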

Compound 3, half-maximal inhibitory concentration: > 100000 nM
Compound 3: no number, only a limit; the forecaster's own chance of this, stated with the estimate: 65%; the middle value is on the limit's open side.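

Going by these compounds alone, compound 1 and compound 3 both stop at a limit of the assay rather than a number, so no step between them can be read: the limit of > 100000 nM in this assay, at which 2 of the 3 values shown sit. Still open, on these data alone, is how far each compound lies past that limit in this assay, and whether this exchange on the sulfonamide nitrogen changes the read-out at all.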